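Aryl swaps on the anilino nitrogen of a shared core

The source may hold more compounds than are shown below. What is called first, only, known or untested is meant among the compounds shown, and "the series" means these compounds.

compound 1 `COc1ccccc1Nc1cc(C)nc(SCc2nc3ccccc3[nH]2)n1` — 34400 nM
compound 2 `Cc1cc(Nc2ccc(F)cc2)nc(SCc2nc3ccccc3[nH]2)n1` — 69500 nM
compound 3 `Cc1cc(NC(C)C)nc(SCc2nc3ccccc3[nH]2)n1` — > 100000 nM (a limit of the assay)

In a functional assay on ECa-109 cells (Homo sapiens) for cytotoxicity, read by MTT assay, with a stated time of 72 h (on this read-out lower numbers stand for stronger inhibition and higher numbers for weaker inhibition), compound 1 gives 34400 nM, the lower of the two plain numbers shown. Compound 2 gives 69500 nM in this assay. Compound 3 reaches only a limit of this assay, > 100000 nM (the limit of > 100000 nM in this assay, at which 1 of the 3 values shown sits). Compound 4 `Cc1cc(Nc2ccc(Cl)cc2)nc(SCc2nc3ccccc3[nH]2)n1` differs from compound 1 by 4-chlorophenyl in place of 2-methoxyphenyl on a nitrogen on an aromatic ring. The step that bears most on it is a 2.0-fold higher number from compound 1 to compound 2 (0.31 log units; beyond the scatter), where 4-fluorophenyl enters the same place; an at least 2.9-fold higher number from compound 1 to compound 3 (0.46 log units; beyond the scatter) shows isopropyl losing more. A 4-chlorophenyl is therefore expected to behave like the 4-fluorophenyl of compound 2, giving a modest rise in the number, estimated at a 1.6-fold higher number from compound 1 to compound 4 (0.20 log units; within the scatter). Compound 4 is expected to give about 55000 nM, within a range from 20000 nM to 150000 nM.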

Compound 4, half-maximal inhibitory concentration: 20400 nM
The estimate for compound 4 lay 2.7-fold (0.43 log units) above the measured number; the range from low to high includes it.
By their numbers in this assay, from the lowest: compounds 4 and 1 (each within the scatter of the next); then compound 2. At a limit, above all of these: compound 3.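

Chloro in place of fluoro on an aromatic carbon gives a 3.4-fold lower number from compound 2 to compound 4 (0.53 log units; beyond the scatter), so the number responds to a single atom on this aryl group, which the earlier compounds did not show. The 4-chlorophenyl in place of 2-methoxyphenyl gives a 1.7-fold lower number from compound 1 to compound 4 (0.23 log units; within the scatter), so these two aryl groups are not separated, while 4-chlorophenyl in place of isopropyl gives an at least 4.9-fold lower number from compound 3 to compound 4 (0.69 log units; beyond the scatter). Compound 3 stands at a limit, not a number: the limit of > 100000 nM in this assay, at which 1 of the 4 values shown sits.

The compounds shown leave open whether bromo or methyl in place of the chloro would hold this gain. They also leave open how an amine or a carboxylic acid on the aryl group would fare.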